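The compounds below may be only part of what the source reports. "The series", "measured", "known", "first", "only" and "open" are said of these compounds alone.

Measured in a functional assay on K562 cells (Homo sapiens) for antiproliferative activity, read by MTT assay, with a stated time of 48 h; a higher number here means a weaker inhibitor, a lower number a stronger inhibitor:

compound 1 `CCn1c(N)c(-c2nc3ccccc3[nH]2)c2nc(C#N)c(C#N)nc21`: > 50000 nM (a limit)
compound 2 `CCN(CC)CCn1c(N)c(-c2nc3ccccc3[nH]2)c2nc(C#N)c(C#N)nc21`: 2490 nM
compound 3 `N#Cc1nc2c(-c3nc4ccccc4[nH]3)c(N)n(CCO)c2nc1C#N`: > 50000 nM (a limit)

Compound 3 gives no number, only the limit > 50000 nM. Compound 4 `CCN(CC)CCCn1c(N)c(-c2nc3ccccc3[nH]2)c2nc(C#N)c(C#N)nc21` has not yet been measured. It differs from compound 3 as follows: (diethylamino)methyl in place of hydroxy on a saturated chain carbon, two bonds along the chain from an aromatic nitrogen. This places (diethylamino)methyl in place of hydroxy on a saturated chain carbon, two bonds along the chain from an aromatic nitrogen, which also reads as 2-hydroxyethyl to 3-(diethylamino)propyl.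

The closest evidence is an at least 20-fold higher number from compound 2 to compound 3 (1.30 log units; beyond the scatter), a large step, together with an at least 20-fold lower number from compound 1 to compound 2 (1.30 log units; beyond the scatter), also large. Both tie the measurable activity to compound 2, which carries a 2-(diethylamino)ethyl chain and gives 2490 nM. Compound 4 keeps the diethylamino group on a longer chain, so a large move toward a lower number is expected in this assay. The expected change is an at least 16-fold lower number from compound 3 to compound 4 (1.22 log units; beyond the scatter).

For compound 4 the estimated value is 3000 nM, with an expected range from 1000 nM to 12000 nM.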

Compound 4, half-maximal inhibitory concentration: 1800 nM
Compound 4: the middle estimate sits 1.7-fold (0.22 log units) above what was measured, and the stated range covers the measured number.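

In this assay, putting 3-(diethylamino)propyl on the aromatic nitrogen in place of the shorter chains without an amine gives an at least 27-fold lower number from compound 3 to compound 4 (1.44 log units; beyond the scatter) and an at least 27-fold lower number from compound 1 to compound 4 (1.44 log units; beyond the scatter), so the gain seen earlier with the diethylamino group also holds on a longer chain. Going from 2-(diethylamino)ethyl to 3-(diethylamino)propyl gives a 1.4-fold lower number from compound 2 to compound 4 (0.14 log units; within the scatter), so the two chain lengths cannot be told apart at this position. The two large steps are only lower bounds, because each starts from a limit: the limit of > 50000 nM in this assay, at which 2 of the 4 values shown sit.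

The compounds shown leave open whether the diethylamino group itself matters or whether another amine, such as dimethylamino or morpholine, would serve equally well on this chain. They also leave open whether a still longer chain carrying the amine would hold this level of activity.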